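Lengthening the alkyl chain of an aryl vinyl ketone

The compounds below may be only part of what the source reports. "The series", "measured", "known", "first", "only" and "open" are said of these compounds alone.

Compound 1 `C=C(C)C(=O)c1ccc(CCCCCCC)cc1`: 23200 nM
Compound 2 `C=CC(=O)c1ccc(CCC)cc1`: 100000 nM
Compound 3 `C=CC(=O)c1ccc(CCCC)cc1`: 66000 nM

In an in vitro assay on BL21-DE3 cells for displacement of a labelled ligand from thyroid hormone receptor beta (Homo sapiens), read by fluorescence polarization (a higher number here means a weaker inhibitor, a lower number a stronger inhibitor), compound 3 gives the second highest of the three numbers. Its nearest neighbour is compound 2, and compound 1 sits clearly lower. Compound 4 `C=CC(=O)c1ccc(CCCCC)cc1` differs from compound 3 by methyl in place of hydrogen on a saturated chain carbon, four bonds along the chain from an aromatic carbon. Among the measured compounds shown here, the one measured step of the same kind, a 1.5-fold lower number from compound 2 to compound 3 (0.18 log units; within the scatter), moved the number down only slightly, so a small step downward in this assay is expected, a 1.5-fold lower number from compound 3 to compound 4 (0.17 log units; within the scatter), most likely still within the scatter. Compound 4 is therefore expected to give about 45000 nM, within a range from 20000 nM to 100000 nM.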

Compound 4, half-maximal inhibitory concentration: 33900 nM
For compound 4 the middle estimate is 1.3-fold (0.12 log units) above the measured one; the range from low to high includes it.
By their numbers in this assay, from the lowest: compounds 1, 4, 3 and 2 (each within the scatter of the next, the first and the last beyond it).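

In this assay the added methyl gives a 1.9-fold lower number from compound 3 to compound 4 (0.29 log units; within the scatter), which alone stays within the usual scatter, as the previous single step did. Across both additions, the change gives a 2.9-fold lower number from compound 2 to compound 4 (0.47 log units; beyond the scatter), so a modest difference beyond the scatter appears only when ethyl replaces hydrogen on the propyl chain of compound 2. Nothing measured here bears on the reason for this difference. As far as these compounds go, whether a longer chain, such as hexyl, would lower the number further stays open. So does the result of replacing the chain with an amine.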